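This account rests on a few compounds, and the source may have more. Where it says the series, first, only, none or still open, it means among the compounds named here.

So far, a physicochemical assay for acid dissociation, has been applied to two compounds sharing one core. Compound 1 (`COc1ccc(CN(CCN(C)C)c2ccccc2)cc1`) gives 9.7 in this assay and compound 2 (`COc1ccc(CN(CCN(C)C)c2ccc(Cl)cc2)cc1`) gives 9.6 in the same test. For the measured compounds named here, compound 2 therefore stands level with the only other measured compound, and the two numbers cannot be told apart.

The next compound to be measured is compound 3 (`COc1ccc(CN(CCN(C)C)c2ccc(N)cc2)cc1`). Its structure differs from that of compound 2 as follows: amino in place of chloro on an aromatic carbon with amino in place of chloro on an aromatic carbon, para to a large group. Going by the values given here, only one measured step bears on this change, namely a number 0.10 log units lower from compound 1 to compound 2 (within the scatter) at an aromatic carbon, and no measured compound yet carries the amino group. That single small step gives no ground for expecting a clear shift, so no step beyond the scatter is expected in this assay for this exchange. The expected step is a number 0.10 log units higher from compound 2 to compound 3 (within the scatter) according to this estimate. For compound 3 the estimated value is 9.7 with an expected range from 9.3 to 10 in this assay once it is measured.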

Compound 3, acid dissociation constant: 9.8
The estimate for compound 3 lay 0.10 log units below the measured number; measured number inside the range.
By their numbers in this assay, from the lowest: compounds 2, 1 and 3 (each within the scatter of the next).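

In this assay, the aromatic carbon para to a large group has now carried hydrogen, chloro and amino, so the comparison no longer rests on a single exchange. Amino, with one hydrogen-bond donor and one hydrogen-bond acceptor, replaces chloro, which has neither, to give a number 0.20 log units higher from compound 2 to compound 3 (within the scatter), and replacing hydrogen with amino gives a number 0.10 log units higher from compound 1 to compound 3 (within the scatter); across compound 1, compound 2 and compound 3, neither a halogen nor a nitrogen substituent at this place separates the numbers beyond the scatter. No measurement available here accounts for this lack of separation between the three compounds.

The compounds shown leave open whether a different group at this same place, such as a nitrile, a carboxylic acid or a longer chain, would also stay within the scatter. They also leave open whether an amino or chloro group placed elsewhere on the shared core would give a step that could be told apart from the scatter in this assay.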